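A New Group on the Carbonyl of Compound 2

The source may hold more compounds than are shown below. What is called first, only, known or untested is meant among the compounds shown, and "the series" means these compounds.

Among the measured compounds shown here, only two compounds have numbers so far. In a functional assay on A20 cells (Mus musculus) for inhibition, with stated times of 1 h, 16 h and 24 h (a higher number here means a weaker inhibitor, a lower number a stronger inhibitor), compound 1 (`N#CCNC(=O)[C@@H]1C[C@@H](S(=O)(=O)c2ccccc2C(F)(F)F)C[C@H]1C(=O)N1CCOCC1`) gives 2 nM. In this assay compound 2 (`N#CC1(NC(=O)[C@@H]2C[C@@H](S(=O)(=O)c3ccccc3)C[C@H]2C(=O)N2CC3CCC(C2)O3)CC1`) gives 16 nM, the higher of the two numbers, which makes it the weaker inhibitor by a gap beyond the scatter. For the measured compounds named here, no measured pair differs in one place only, so nothing yet shows what a single change does. Compound 3 (`CC1CCN(C(=O)[C@@H]2C[C@H](S(=O)(=O)c3ccccc3)C[C@H]2C(=O)NC2(C#N)CC2)CC1`) departs from compound 2 on a carbonyl carbon, where 4-methylpiperidin-1-yl enters: a group of 7 heavy atoms (6 carbon, 1 nitrogen; one six-membered non-aromatic ring with 1 hetero atom) in place of a group of 8 heavy atoms (6 carbon, 1 nitrogen, 1 oxygen; one five-membered non-aromatic ring with 1 hetero atom, one six-membered non-aromatic ring with 2 hetero atoms), on a carbonyl carbon. Going by the values given here, with no measured step to go by, the expected change in this assay, a 1.3-fold higher number from compound 2 to compound 3 (0.10 log units; within the scatter), is slightly upward and lies within the scatter. The expectation therefore stays near compound 2, at 16 nM. For compound 3 the estimated value is 20 nM, with an expected range from 6 nM to 65 nM.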

Compound 3, half-maximal inhibitory concentration: 2 nM
Estimate against measurement, compound 3: 10-fold (1.00 log units) above; the whole stated range lies above it.
By their numbers in this assay, from the lowest: compounds 1 and 3 (each within the scatter of the next); then compound 2.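

Among the compounds shown here, this is the first single change with a measured result. In this assay, 4-methylpiperidin-1-yl on the carbonyl carbon gives an 8.0-fold lower number from compound 2 to compound 3 (0.90 log units; beyond the scatter) and so shows that the group held at this place, whose other neighbour on the carbonyl is a saturated ring carbon, can move the number beyond the scatter. The lower number goes with the single six-membered ring that carries no oxygen, but nothing measured here explains the step.

The compounds shown leave open how plain piperidin-1-yl, without the methyl, or the smaller pyrrolidin-1-yl would stand on this carbonyl carbon, so the part played by the methyl remains unknown. From the compounds shown here alone, it also remains open whether a 4-hydroxypiperidin-1-yl group, with a hydroxyl in place of that methyl, would keep the number of compound 3.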